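A few compounds are considered here, and "the series" means these few. Any claim that something is new, unique, unknown or untested is made for them only; others in the source may bear on it.

Compound 1 `COc1cc(/C=C/C(=O)O)ccc1OC(=O)c1nc(C)c(C)nc1C` gives 69400 nM
Compound 2 `COc1cc(/C=C/C(=O)O)cc(OC)c1OC(=O)c1nc(C)c(C)nc1C` gives 34700 nM

Both numbers come from a functional assay on EA.hy 926 cells (Homo sapiens) for cytotoxicity, read by MTT assay, with stated times of 24 h and 12 h (on this read-out higher numbers stand for an effect only at larger amounts of compound and lower numbers for an effect already at smaller amounts), and are the only two available, and compound 1 stands within the scatter of compound 2. Compound 3 (`Cc1nc(C)c(C(=O)Oc2ccc(/C=C/C(=O)O)cc2)nc1C`) has hydrogen in place of methoxy on an aromatic carbon of compound 1 (hydrogen in place of methoxy on an aromatic carbon). For the measured compounds named here, the only measured step that bears on this is the reverse kind of change, methoxy in place of hydrogen on an aromatic carbon (a 2.0-fold lower number from compound 1 to compound 2 (0.30 log units; within the scatter)). With so small a precedent, no step beyond the scatter is expected in this assay, at most a slight drift towards a higher number. The estimated step is small (a 1.3-fold higher number from compound 1 to compound 3 (0.11 log units; within the scatter)). Compound 3 is estimated at 90000 nM (from 40000 nM to 200000 nM).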

Compound 3, half-maximal effective concentration: 38000 nM
For compound 3 the middle estimate is 2.4-fold (0.37 log units) above the measured one; measured number below the stated range.
By their numbers in this assay, from the lowest: compounds 2, 3 and 1 (each within the scatter of the next).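

In this assay, hydrogen in place of methoxy at this position, ortho to a large group and meta to a 2-carboxyethenyl group, gives a 1.8-fold lower number from compound 1 to compound 3 (0.26 log units; within the scatter). Until now only the addition of a methoxy to compound 1 had been seen, and the removal of one also stays within the scatter, so this position shows no readable effect of methoxy in either direction. No measurement on hand offers an explanation for this result. From the compounds shown here alone, it remains open whether a hydroxyl, an amine or a longer alkoxy chain at this position would produce a step beyond the scatter.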